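The source may report more compounds than this note shows. Statements on the series, on what has been measured and on what is new or still open speak of the compounds shown alone.

Compound 1 `CCOc1cccc(-c2ncnn2-c2cc(OC)c(OC)c(OC)c2)c1` and compound 2 `COc1cc(-n2ncnc2-c2ccccc2)cc(OC)c1OC` share a common core. In a functional assay on HL-60 cells (Homo sapiens) for antiproliferative activity, read by MTT assay, with a stated time of 72 h (on this read-out lower numbers stand for stronger inhibition and higher numbers for weaker inhibition), compound 1 reaches only the assay limit > 10000 nM. In this assay compound 2 likewise gives only the limit > 10000 nM. The step that the two limits leave unreadable from compound 1 to compound 2 therefore stays unreadable, and the limit of > 10000 nM in this assay, at which 2 of the 2 values shown sit, is the sole anchor for the series. Compound 3 `COc1cc(-n2ncnc2-c2cccc(F)c2)cc(OC)c1OC` carries fluoro in place of hydrogen on an aromatic carbon, which one bond further out reads phenyl to 3-fluorophenyl. Among the measured compounds shown here, no measured step tracks this change, so for this assay no shift beyond the scatter is expected: a step that the limit leaves unreadable from compound 2 to compound 3 is the estimated step, with compound 3 likely again reporting only a limit. Compound 3 is estimated at 15000 nM, between 5000 nM and 50000 nM.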

Compound 3, half-maximal inhibitory concentration: > 10000 nM
Compound 3 ended at the assay's limit (the forecaster's own chance of this, stated with the estimate: 75%); the middle value does not contradict the limit.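

No new step can be read among compound 1, compound 2 and compound 3, each of which gives only a limit: the limit of > 10000 nM in this assay, at which 3 of the 3 values shown sit. Going by these compounds, whether ethoxy, fluoro and hydrogen on the aromatic carbon differ at all in this assay stays open.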